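A Methylphenyl Exchange at the Cytotoxicity Limit

The source may report more compounds than this note shows. Statements on the series, on what has been measured and on what is new or still open speak of the compounds shown alone.

Compound 3 `Cc1cccc(OCCCCCn2ccc(=O)[nH]c2=O)c1` is one of three compounds examined in an ADME assay on HEL cells (Homo sapiens) for cytotoxicity; a higher number here means that more compound is tolerated, a lower number that less compound is tolerated. In this assay compound 3 gives only a limit, > 100000 nM. Compound 1 `O=c1ccn(CCCCCOc2ccccc2)c(=O)[nH]1` likewise reaches only the limit > 100000 nM. Compound 2 `Cc1ccccc1OCCCCCn1ccc(=O)[nH]c1=O` also gives the limit > 100000 nM. The steps a step that the two limits leave unreadable from compound 1 to compound 2, a step that the two limits leave unreadable from compound 1 to compound 3 and a step that the two limits leave unreadable from compound 2 to compound 3 cannot be sized because of the limit of > 100000 nM in this assay, at which 3 of the 3 values shown sit. Compound 4 `Cc1ccc(OCCCCCn2ccc(=O)[nH]c2=O)cc1` differs from compound 3 by 4-methylphenyl in place of 3-methylphenyl on an oxygen on a saturated carbon. Every measured step that bears on this change is unreadable, so no step beyond the scatter is expected in this assay. Compound 4 is expected to remain at the same limit, with the expected step being a number no higher from compound 3 to compound 4 (the limit leaves the size open). The estimate for compound 4 is 100000 nM, between 50000 nM and 200000 nM.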

Compound 4, half-maximal cytotoxic concentration: > 100000 nM
Compound 4: a limit, no number (the forecaster's own chance of this, stated with the estimate: 90%); the middle value lies on the limit itself.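

Among the compounds shown here, compound 4 also gives only a limit, so no step from compound 1, compound 2 or compound 3 to compound 4 can be read: the limit of > 100000 nM in this assay, at which 4 of the 4 values shown sit. The compounds shown leave open whether the hydrogen, 2-methylphenyl, 3-methylphenyl and 4-methylphenyl variants differ in tolerated concentration at all.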